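A pyridyl ring in place of the trifluoromethylphenyl group

The source may report more compounds than this note shows. Statements on the series, on what has been measured and on what is new or still open speak of the compounds shown alone.

Compound 2 `O=C(O)C[C@H](O)C[C@H](O)CCn1c(C(F)(F)F)nc(-c2ccc(F)cc2)c1-c1ccc(C(F)(F)F)cc1` is the reference for this step. In an assay on microsomes from liver for inhibition of 3-hydroxy-3-methylglutaryl-coenzyme A reductase (Rattus norvegicus) (on this read-out lower numbers stand for stronger inhibition and higher numbers for weaker inhibition), compound 2 gives > 1000 nM, which is a limit of the assay and not a number. Compound 1 `COc1cccc(-c2c(-c3ccc(F)cc3)nc(C(F)(F)F)n2CC[C@@H](O)C[C@@H](O)CC(=O)O)c1` carries a 3-methoxyphenyl group at the same carbon, and in this assay compound 1 gives 135 nM. Among the compounds with values here, the single measured step, an at least 7.4-fold higher number from compound 1 to compound 2 (0.86 log units; beyond the scatter), runs from a number to a limit, so its true size is only bounded from below (the limit of > 1000 nM in this assay, at which 1 of the 2 values shown sits). Compound 3 `O=C(O)C[C@H](O)C[C@H](O)CCn1c(C(F)(F)F)nc(-c2ccc(F)cc2)c1-c1cccnc1` alters the same position once more: pyridin-3-yl in place of 4-(trifluoromethyl)phenyl on an aromatic carbon. Within the data shown here, no measured compound carries a pyridin-3-yl group, so the expectation rests on the one exchange seen at this carbon and on the value of compound 1. For compound 3 the expected step is an at least 2.8-fold lower number from compound 2 to compound 3 (0.45 log units; beyond the scatter), a return from the limit to a measurable number. The estimate for compound 3 is 350 nM, within 80 nM to 1500 nM.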

Compound 3, half-maximal inhibitory concentration: > 1000 nM
Compound 3 was reported as a limit (the forecaster's own chance of this, stated with the estimate: 25%); middle value at least 2.8-fold (0.45 log units) away from the limit.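

At this carbon, the result shows that a nitrogen-containing pyridin-3-yl ring, with fewer heavy atoms than 4-(trifluoromethyl)phenyl, also fails to retain the result of the 3-methoxyphenyl group in this assay: the exchange gives an at least 7.4-fold higher number from compound 1 to compound 3 (0.86 log units; beyond the scatter) and so adds a second group to the first on the weak side of compound 1. Of the three aryl groups shown, only the 3-methoxyphenyl group of compound 1 gives a number. The step between the other two compounds cannot be read because both stand at the same limit of the assay: the limit of > 1000 nM in this assay, at which 2 of the 3 values shown sit.

From the compounds shown here alone, how far compound 2 and compound 3 lie beyond that limit remains open. Also open, going by these compounds, is whether a 4-methoxyphenyl, 3-hydroxyphenyl or 3-aminophenyl group at this carbon would give a number, which would show how much the methoxy group and its ring position matter.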